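Shifting Fluorine and Adding Methyl on the Pendant Ring

This account rests on a few compounds, and the source may have more. Where it says the series, first, only, none or still open, it means among the compounds named here.

Compound 2 `CCC1=C(O)c2c(oc(-c3ccc(F)cc3)cc2=O)C(CC)(CC)C1=O` gives 33 uM in a functional assay on KB cells (Homo sapiens) for antiproliferative activity, read by sulforhodamine B assay, with a stated time of 3 days (on this read-out lower numbers stand for an effect already at smaller amounts and higher numbers for an effect only at larger amounts of compound), the only plain number shown. In this assay compound 1 `CCCOc1ccc(-c2cc(=O)c3c(o2)C(CC)(CC)C(=O)C(CC)=C3O)cc1` stands at > 50.5 uM, which is a limit of the assay (the limit of > 50.5 uM in this assay, at which 1 of the 2 values shown sits). Within the data shown here, the one measured step, an at least 1.5-fold lower number from compound 1 to compound 2 (0.18 log units; that floor lies within the scatter), concerns a different part of the pendant ring. Compound 3 `CCC1=C(O)c2c(oc(-c3ccc(C)c(F)c3)cc2=O)C(CC)(CC)C1=O` carries 3-fluoro-4-methylphenyl in place of 4-fluorophenyl on an aromatic carbon. Among the measured compounds shown here, no measured step bears on this change, so no shift beyond the scatter is expected in this assay. The expected step is no change at the digits printed from compound 2 to compound 3 (within the scatter). Compound 3 is therefore estimated at 33 uM, ranging from 12 uM to 90 uM.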

Compound 3, concentration for half-maximal effect: 28.1 uM
Beside the measured number, compound 3's estimate is 1.2-fold (0.07 log units) above it; measured number inside the range.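

In this assay, 3-fluoro-4-methylphenyl in place of 4-fluorophenyl on this aromatic carbon gives a 1.2-fold lower number from compound 2 to compound 3 (0.07 log units; within the scatter), so adding a methyl and shifting the fluorine together produce no shift beyond the scatter at this position. Unlike the earlier step, this one joins two plain numbers and so has a readable size. Compound 1 remains the only compound at a limit of the assay: the limit of > 50.5 uM in this assay, at which 1 of the 3 values shown sits.

Going by these compounds, whether an amine, a carboxylic acid or a longer chain on the pendant ring would move the number beyond the scatter stays open. On these data alone, the separate shares of the methyl and the shifted fluorine also stay open, as this step carries both at once.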